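Swapping the Thiophene of Compound 3 for a Fluorinated Aryl Ring

The compounds below may be only part of what the source reports. "The series", "measured", "known", "first", "only" and "open" are said of these compounds alone.

Measured in a functional assay on DU-145 cells (Homo sapiens) for inhibition, read by trypan blue exclusion, with a stated time of 96 h; a lower number here means a stronger inhibitor of growth, a higher number a weaker inhibitor of growth:
- Compound 1 `O=C(/C(=C\c1ccc(Cl)cc1)S(=O)(=O)c1ccc(Br)cc1)c1ccc(Br)cc1`: 50000 nM
- Compound 2 `Cc1ccc(S/C(=C/c2c[nH]c3ccccc23)C(=O)c2ccc(Br)cc2)cc1`: 10000 nM
- Compound 3 `Cc1ccc(S/C(=C/c2sccc2C)C(=O)c2ccc(Br)cc2)cc1`: 50000 nM

Compound 3, at 50000 nM, stands level with compound 1, and together they hold the highest of the three numbers. Compound 4 `Cc1ccc(S/C(=C/c2ccc(F)c(C)c2)C(=O)c2ccc(Br)cc2)cc1` carries 4-fluoro-3-methylphenyl in place of 3-methylthiophen-2-yl, on a double-bonded chain carbon bound to a double-bonded chain carbon: 4-fluoro-3-methylphenyl in place of 3-methylthiophen-2-yl on a double-bonded chain carbon bound to a double-bonded chain carbon.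

Going by the values given here, one measured step bears on this place: a 5.0-fold higher number from compound 2 to compound 3 (0.70 log units; beyond the scatter). That modest step shows that changing the group here can shift the number in this assay. No measurement tests this particular swap, and compound 1 differs from compound 3 in more than one place, so it offers no clean comparison. A small shift toward a lower number is therefore expected, smaller than that one measured step and not clearly beyond the scatter. The expected change is a 1.7-fold lower number from compound 3 to compound 4 (0.22 log units; within the scatter). For compound 4 the estimated value is 30000 nM, with an expected range from 9000 nM to 60000 nM.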

Compound 4, concentration for 50% growth inhibition: 25000 nM
Compound 4: middle estimate off by 1.2-fold (0.08 log units), on the high side; the range from low to high includes it.
By their numbers in this assay, from the lowest: compound 2; then compounds 4, 1 and 3 (each within the scatter of the next).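

In this assay, replacing 3-methylthiophen-2-yl with 4-fluoro-3-methylphenyl gives a 2.0-fold lower number from compound 3 to compound 4 (0.30 log units; within the scatter), so a five-membered sulfur-containing ring and a six-membered all-carbon ring cannot be told apart at this place, despite the added fluorine and the larger group. Set against 1H-indol-3-yl, the new group gives a 2.5-fold higher number from compound 2 to compound 4 (0.40 log units; beyond the scatter), so the indole now stands apart from two different groups at this place, not just one. Nothing available explains these results.

Going by these compounds, what stays open is how a ring carrying an amine or a carboxylic acid would read at this place in this assay. Also open, on these data alone, is whether the fluorine and the methyl of 4-fluoro-3-methylphenyl matter separately, as a lone fluorine or a lone methyl on the ring might show.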